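Adding a Butylamino Group to Compound 2

This account rests on a few compounds, and the source may have more. Where it says the series, first, only, none or still open, it means among the compounds named here.

For the measured compounds named here, in a functional assay on NCI-H460 cells (Homo sapiens) for cytotoxicity, read by MTT assay, with a stated time of 72 h (a higher number here means a weaker inhibitor, a lower number a stronger inhibitor), compound 2 `CC(C)(C)C1=CC(=O)C=CC1=O` gives 72000 nM, the highest of the two numbers measured so far. Compound 1 `CCCCNC1=CC(=O)C=C(C(C)(C)C)C1=O` gives 13000 nM, which makes compound 2 the weaker inhibitor of the pair. Compound 3 `CCCCNC1=CC(=O)C(C(C)(C)C)=CC1=O` has not yet been measured. It differs from compound 2 by one change, butylamino in place of hydrogen on a double-bonded ring carbon.

Going by the values given here, only one measured step bears on this change: a 5.5-fold higher number from compound 1 to compound 2 (0.74 log units; beyond the scatter), with hydrogen replacing butylamino. Read in reverse, this modest step suggests that adding butylamino should bring the number down. However, compound 1 and compound 3 carry the group on different ring carbons, so the size of the step may not carry over, and a single step is thin evidence. A drop of similar size in this assay is still the best available expectation, and the estimated step is a 4.5-fold lower number from compound 2 to compound 3 (0.65 log units; beyond the scatter). For compound 3 the estimated value is 16000 nM, with an expected range from 5000 nM to 50000 nM.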

Compound 3, half-maximal inhibitory concentration: 72000 nM
For compound 3 the middle estimate is 4.5-fold (0.65 log units) below the measured one; measured number outside the range, above it.
By their numbers in this assay, from the lowest: compound 1; then compounds 2 and 3 (each within the scatter of the next).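

In this assay, butylamino on this double-bonded ring carbon, three ring bonds from the ring atom that bears a tert-butyl group, makes no difference that can be told from the scatter: no change at the digits printed from compound 2 to compound 3 (within the scatter). For the compounds shown here, the earlier compounds offered only one view of this group, with butylamino on a different ring carbon in compound 1, and there removing it gave a 5.5-fold higher number from compound 1 to compound 2 (0.74 log units; beyond the scatter), so the same group on the same core does not give the same step at every ring carbon. Nothing shown here explains why the two ring carbons differ.

The compounds shown leave open whether this lack of a step is particular to butylamino, or would also hold for a shorter chain such as methylamino or a longer one such as hexylamino on the same ring carbon. They also leave open how a ring amine such as morpholine, or a carboxylic acid at the end of the chain, would read at this ring carbon.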